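This account rests on a few compounds, and the source may have more. Where it says the series, first, only, none or still open, it means among the compounds named here.

Compound 1 `COc1ccc2c(=O)c(/C=C/C(=O)Nc3cccc(C)c3)coc2c1`: 554000 nM. Compound 2 `COc1ccc(CNC(=O)/C=C/c2coc3cc(OC)ccc3c2=O)cc1`: 43000 nM.

In an ADME assay on HepG2 2.2.15 cells (Homo sapiens) for cytotoxicity, read by MTT assay, with stated times of 48 h and 9 days (a higher number here means that more compound is tolerated, a lower number that less compound is tolerated), compound 1 stands highest of the two numbers; its nearest neighbour is compound 2, and the step of a 13-fold lower number from compound 1 to compound 2 (1.11 log units; beyond the scatter) lies beyond the scatter. Compound 3 `COc1ccc2c(=O)c(/C=C/C(=O)Nc3ccc(F)cc3)coc2c1` differs from compound 1 by 4-fluorophenyl in place of 3-methylphenyl on an amide-type nitrogen. Within the data shown here, no measured step covers an exchange of one aryl group on the amide-type nitrogen for another, so the single known step does not bear on it directly. Compound 3 is therefore expected to stay near compound 1, with no step beyond the scatter, and the estimated value is 400000 nM (range 150000 nM to 900000 nM), a step of a 1.4-fold lower number from compound 1 to compound 3 (0.14 log units; within the scatter).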

Compound 3, half-maximal cytotoxic concentration: 743000 nM
For compound 3 the middle estimate is 1.9-fold (0.27 log units) below the measured one; measured number inside the range.
By their numbers in this assay, from the lowest: compound 2; then compounds 1 and 3 (each within the scatter of the next).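

In this assay one aryl group on the amide-type nitrogen gives way to another in a 1.3-fold higher number from compound 1 to compound 3 (0.13 log units; within the scatter) and the number stays within the scatter, which the earlier pair could not show. The other new comparison is a 17-fold higher number from compound 2 to compound 3 (1.24 log units; beyond the scatter) and it leaves the 4-methoxybenzyl compound 2 apart from both aryl amides. Nothing measured here explains either step.

Still open, as far as these compounds go, is whether a plain benzyl or a 4-methoxyphenyl group on the same nitrogen would stand with compound 2 or with compounds 1 and 3. Also open, from the compounds shown here alone, is whether a carboxylic acid on the phenyl ring would change the number.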